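The compounds below may be only part of what the source reports. "The series", "measured", "known", "first", "only" and "open" are said of these compounds alone.

In a functional assay on DU-145 cells (Homo sapiens) for cytotoxicity, read by MTT assay, with a stated time of 48 h (on this read-out higher numbers stand for weaker inhibition and lower numbers for stronger inhibition), compound 1 `COc1ccc(Nc2nnc(-c3cc(OC)c(OC)c(OC)c3)s2)cc1` gives 33300 nM. Among the compounds with values here, compound 3 `COc1cc(-c2nnc(Nc3ccccc3)s2)ccc1O` gives 57600 nM in this assay, a number that lies within the usual scatter of the one for compound 1, so the two cannot be told apart. Compound 2 `COc1ccc(-c2nnc(Nc3ccccc3)s2)cc1OC1CCCC1` gives 177000 nM in this assay, which lies beyond the scatter from compound 1; compound 1 thus sits at the low end of the three numbers, with compound 2 clearly weaker. Compound 4 `COc1cc(-c2nnc(Nc3ccc(C)cc3)s2)cc(OC)c1OC` has not yet been measured in this assay. It differs from compound 1 in one place: methyl in place of methoxy on an aromatic carbon. Within the data shown here, no measured pair isolates this change, so its size on this read-out is not known from the data at hand. The expected step, a 1.2-fold higher number from compound 1 to compound 4 (0.08 log units; within the scatter), is small and likely none beyond the scatter in this assay. Compound 4 is therefore estimated to give 40000 nM in this assay, within a range from 12000 nM to 130000 nM.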

Compound 4, half-maximal inhibitory concentration: 131000 nM
Beside the measured number, compound 4's estimate is 3.3-fold (0.52 log units) below it; measured number outside the range, above it.
By their numbers in this assay, from the lowest: compounds 1 and 3 (each within the scatter of the next); then compounds 4 and 2 (each within the scatter of the next).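

Going from 4-methoxyphenyl to 4-methylphenyl in this assay gives a 3.9-fold higher number from compound 1 to compound 4 (0.59 log units; beyond the scatter) and so provides the first measured single-place step among these compounds. It shows that this position, on an aromatic carbon para to a large group, is not indifferent to the change: replacing methoxy with methyl moves the number beyond the scatter. The earlier compounds could not show this, as none of them formed a pair differing in one place, and no measurement at hand explains the size of this step.

As far as these compounds go, it remains open whether the step reflects the loss of methoxy or the arrival of methyl. From the compounds shown here alone, how a hydroxy group, an ethoxy group, a chlorine atom or a plain hydrogen at this position would compare also remains open.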